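A few compounds are considered here, and "the series" means these few. Any claim that something is new, unique, unknown or untested is made for them only; others in the source may bear on it.

Compound 1 `C=CCN(CCCC(=O)O)C(=O)/C(C)=C/c1ccc(C(=O)Oc2ccc(C(=N)N)cc2)cc1` carries an allyl group on its amide-type nitrogen. In an in vitro ADME assay on a cell-free system (plasma) for pharmacokinetics (on this read-out lower numbers stand for a shorter-lived compound and higher numbers for a longer-lived compound), compound 1 gives > 1 h, which is a limit of this assay rather than a number (the limit of > 1 h in this assay, at which 1 of the 2 values shown sits). Compound 2 `CCOC(=O)CN(Cc1ccccc1)C(=O)/C(C)=C/c1ccc(C(=O)Oc2ccc(C(=N)N)cc2)cc1` pairs a benzyl group with an ethyl ester. In this assay compound 2 gives < 0.0167 h, again only a limit (the limit of < 0.0167 h in this assay, at which 1 of the 2 values shown sits). Compound 3 `CCOC(=O)C(C(=O)OCC)N(CCCC(=O)O)C(=O)/C(C)=C/c1ccc(C(=O)Oc2ccc(C(=N)N)cc2)cc1` differs from compound 1 by bis(ethoxycarbonyl)methyl in place of allyl on an amide-type nitrogen. Among the compounds with values here, no measured step links two compounds here. The step from compound 1 to compound 3 is expected to shorten the half-life, as an at least 5.0-fold lower number from compound 1 to compound 3 (0.69 log units; beyond the scatter), because compound 2 with its ethyl ester gives < 0.0167 h. Compound 3 is therefore expected to give 0.2 h, between 0.02 h and 1.5 h.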

Compound 3, half-life: 0.483 h
Estimate against measurement, compound 3: 2.4-fold (0.38 log units) below; measured number inside the range.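

In this assay, bis(ethoxycarbonyl)methyl in place of allyl on an amide-type nitrogen gives an at least 2.0-fold lower number from compound 1 to compound 3 (0.31 log units; beyond the scatter). Within the data shown here, this is the first comparison in which only this group differs, so it shows that a change at this one place can alter the half-life beyond the usual scatter. The step has only a lower bound, as compound 1 sits at a limit and not at a number: the limit of > 1 h in this assay, at which 1 of the 3 values shown sits.

The compounds shown leave open how large the full step is. They also leave open how a single ethyl ester, an amine or a propyl chain at this place would compare.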